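The source may hold more compounds than are shown below. What is called first, only, known or untested is meant among the compounds shown, and "the series" means these compounds.

Within the data shown here, compound 2 `O=C(/C=C/c1ccc(OCc2cn(Cc3cccc(F)c3)nn2)cc1)c1ccc(Br)cc1` gives 34% in a functional assay on MIA PaCa-2 cells (Homo sapiens) for inhibition, read by MTT assay, with a stated time of 48 h, tested at 10 uM (on this read-out higher numbers stand for more inhibition of growth at the one concentration tested and lower numbers for less inhibition of growth), the second highest of the three numbers measured so far. Its nearest neighbour is compound 3 `O=C(/C=C/c1ccc(OCc2cn(Cc3ccc(F)cc3)nn2)cc1)c1ccc(Br)cc1`, which gives 32% in this assay; the step of a number 2 percentage points lower from compound 2 to compound 3 (within the scatter) lies within the scatter. Furthest away is compound 1 `O=C(/C=C/c1ccc(OCc2cn(Cc3cccc(Br)c3)nn2)cc1)c1ccc(Br)cc1`, which gives 43% in this assay, and the step of a number 9 percentage points lower from compound 1 to compound 2 (within the scatter) also stays within the scatter. So far all three compounds sit close together.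

Compound 4 `COc1ccc(C(=O)/C=C/c2ccc(OCc3cn(Cc4cccc(F)c4)nn3)cc2)cc1` differs from compound 2 by one change: methoxy in place of bromo on an aromatic carbon. Among the measured compounds shown here, no measured step touches this part of the shared core. For the measured compounds named here, the only step that exchanged a bromo, a number 9 percentage points lower from compound 1 to compound 2 (within the scatter), did so at a different place and stayed within the scatter, and the change of one phenyl for another, a number 2 percentage points lower from compound 2 to compound 3 (within the scatter), was likewise small. There is therefore no ground to expect a step beyond the scatter in this assay in either direction. Compound 4 is expected to give about 34%, between 18% and 50%, an estimated step of no change at the digits printed from compound 2 to compound 4 (within the scatter).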

Compound 4, percent growth inhibition at one concentration: 48%
The estimate for compound 4 lay 14 percentage points below the measured number; the range from low to high includes it.
By their numbers in this assay, from the lowest: compounds 3, 2, 1 and 4 (each within the scatter of the next, the first and the last beyond it).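

All three earlier compounds share the same (4-bromophenyl)carbonyl part, so they could say nothing about this position. Methoxy in place of bromo on this aromatic carbon gives a step of a number 14 percentage points higher from compound 2 to compound 4 (beyond the scatter) in this assay, which shows that a single exchange at this place can move the growth inhibition by more than repeat measurements would. Nothing at hand explains why the number rises with this exchange.

As far as these compounds go, it remains open whether the same exchange would raise the number when the 3-fluorophenyl of compound 4 is replaced by the 3-bromophenyl of compound 1 or the 4-fluorophenyl of compound 3. From the compounds shown here alone, it is also open how a plain hydrogen, a hydroxy, an amine, a carboxylic acid or a longer chain such as ethoxy would read at this position.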